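The source may hold more compounds than are shown below. What is called first, only, known or untested is meant among the compounds shown, and "the series" means these compounds.

Measured so far in a functional assay on CHO cells for antagonist activity at Orexin/Hypocretin receptor type 1 (Homo sapiens), read by FLIPR and calcium flux; on this read-out higher numbers stand for weaker inhibition and lower numbers for stronger inhibition:
- compound 1 `COc1ccc(C)cc1NC(=O)CSc1nnc(-c2ccoc2C)n1Cc1ccco1`: 2510 nM
- compound 2 `Cc1occc1-c1nnc(SCC(=O)Nc2cccc(F)c2)n1Cc1ccco1`: a limit of the assay, > 15800 nM
- compound 3 `Cc1occc1-c1nnc(SCC(=O)Nc2ccc(Cl)cc2)n1Cc1ccco1`: 2000 nM

Compound 1 holds the highest of the two numbers; the step of a 1.3-fold lower number from compound 1 to compound 3 (0.10 log units; within the scatter) is within the scatter, so no order between compound 1 and compound 3 is claimed. Compound 4 `Cc1occc1-c1nnc(SCC(=O)Nc2cccc(Cl)c2)n1Cc1ccco1` is not yet measured; it differs from compound 1 by 3-chlorophenyl in place of 2-methoxy-5-methylphenyl on an amide-type nitrogen. Among the compounds with values here, two measured steps bear on it. The 3-fluorophenyl analogue reaches only a limit, (the limit of > 15800 nM in this assay, at which 1 of the 3 values shown sits), giving an at least 6.2-fold higher number from compound 1 to compound 2 (0.79 log units; beyond the scatter) and an at least 7.9-fold lower number from compound 2 to compound 3 (0.89 log units; beyond the scatter); the 4-chlorophenyl analogue gives a 1.3-fold lower number from compound 1 to compound 3 (0.10 log units; within the scatter). Chlorine at the 3-position is thus expected to behave more like compound 2 than compound 3, with a higher number than compound 1 beyond the scatter. Compound 4 is accordingly estimated at 8000 nM (range 2500 nM to 25000 nM), an expected step of a 3.2-fold higher number from compound 1 to compound 4 (0.50 log units; beyond the scatter).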

Compound 4, inhibition constant: 2000 nM
The estimate for compound 4 lay 4.0-fold (0.60 log units) above the measured number; measured number below the stated range.
By their numbers in this assay, from the lowest: compounds 3, 4 and 1 (each within the scatter of the next). At a limit, above all of these: compound 2.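

In this assay, 3-chlorophenyl and 4-chlorophenyl on the amide-type nitrogen cannot be told apart, no change at the digits printed from compound 3 to compound 4 (within the scatter), and 3-chlorophenyl also matches the 2-methoxy-5-methylphenyl group, a 1.3-fold lower number from compound 1 to compound 4 (0.10 log units; within the scatter). The loss seen with the 3-fluorophenyl group therefore does not extend to every group with a substituent at that position, as chloro in place of fluoro gives an at least 7.9-fold lower number from compound 2 to compound 4 (0.89 log units; beyond the scatter). That step starts from a limit, not a number: the limit of > 15800 nM in this assay, at which 1 of the 4 values shown sits.

Still open, on these data alone, is whether unsubstituted phenyl reads like compound 2 or compound 4. Bromo in place of chloro on the aromatic carbon is equally open.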